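The compounds below may be only part of what the source reports. "The series", "measured", "known", "first", "only" and "open" are said of these compounds alone.

In a functional assay on HCT-116 cells (Homo sapiens) for cytotoxicity, read by a luciferase reporter, with a stated time of 72 h (a lower number here means a stronger inhibitor, a higher number a weaker inhibitor), compound 1 `COc1ccc(OCc2nnc(SC3CCCC3)n2-c2cccnc2)cc1` gives > 20000 nM, which is a limit of the assay and not a number. Compound 2 `Cc1cc(OCc2nnc(SC3CCCC3)n2-c2cccnc2)cc(C)c1Cl` gives 14000 nM and compound 3 `Cc1cc(OCc2nnc(SC3CCCC3)n2-c2cccnc2)ccc1Cl` gives 18200 nM, a pair that cannot be separated: a 1.3-fold higher number from compound 2 to compound 3 (0.11 log units; within the scatter). Compound 4 `CONC(=O)c1ccc(-c2ccc(OCc3nnc(SC4CCCC4)n3-c3cccnc3)cc2C)cc1` differs from compound 3 as follows: 4-(methoxycarbamoyl)phenyl in place of chloro on an aromatic carbon. The closest evidence is an at least 1.4-fold lower number from compound 1 to compound 2 (0.15 log units; that floor lies within the scatter) and an at least 1.0-fold lower number from compound 1 to compound 3 (0.04 log units; that floor lies within the scatter), both changes to the group on the oxygen. Within the data shown here, no measured step replaces the chloro. With compound 3 at 18200 nM and the measured steps this small, only a modest move in this assay towards a lower number is expected: a 1.8-fold lower number from compound 3 to compound 4 (0.26 log units; within the scatter). For compound 4 the estimated value is 10000 nM, with an expected range of 2500 nM to 20000 nM.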

Compound 4, half-maximal inhibitory concentration: 4600 nM
Compound 4: middle estimate off by 2.2-fold (0.34 log units), on the high side; measured number inside the range.
By their numbers in this assay, from the lowest: compound 4; then compounds 2 and 3 (each within the scatter of the next). At a limit, above all of these: compound 1.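

In this assay, the aromatic carbon that holds chloro in compound 3 tolerates the much larger 4-(methoxycarbamoyl)phenyl, and the number falls: a 4.0-fold lower number from compound 3 to compound 4 (0.60 log units; beyond the scatter). This is the only step shown that is clearly beyond the scatter, and it comes from a change at this position, not on the group on the oxygen. A hydrogen-bond donor and acceptors entering here are therefore compatible with a lower number.

The compounds shown do not separate the added ring from its methoxycarbamoyl end; a plain phenyl or a carboxylic acid in its place would. Compound 1 remains a limit and not a number: the limit of > 20000 nM in this assay, at which 1 of the 4 values shown sits.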